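Cytotoxicity notes: piperazinyl replacing methyl on the shared core

The source may report more compounds than this note shows. Statements on the series, on what has been measured and on what is new or still open speak of the compounds shown alone.

Measured compounds:
- compound 1, `O=c1nc(-c2ccccc2)c2cc(-c3cc[nH]n3)ccc2[nH]1`; in an ADME assay on L6 cells (Rattus norvegicus) for cytotoxicity, read by fluorescence and resazurin assay, with a stated time of 72 h (on this read-out lower numbers stand for an effect already at smaller amounts and higher numbers for an effect only at larger amounts of compound), compound 1 gives > 50000 nM, a limit of the assay.
- compound 2, `Cc1ccc2[nH]c(=O)nc(-c3ccccc3)c2c1`; in this assay compound 2 gives > 50000 nM, again a limit and not a number.

The step from compound 1 to compound 2, a step that the two limits leave unreadable from compound 1 to compound 2, cannot be read because both values are limits. Within the data shown here, compound 2 therefore stands only at the limit of the assay, and the same holds for the one further value shown, as both sit at the limit of > 50000 nM in this assay, at which 2 of the 2 values shown sit.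

Compound 3, `O=c1nc(-c2ccccc2)c2cc(N3CCNCC3)ccc2[nH]1`, differs from compound 2 by piperazin-1-yl in place of methyl on an aromatic carbon. Among the measured compounds shown here, the only measured step touching this position is the unreadable one from compound 1 to compound 2, so no direction and no size can be taken from it. No change beyond the scatter is expected in this assay, and the expected step is a step that the limit leaves unreadable from compound 2 to compound 3. For compound 3 the estimate is 80000 nM, within 30000 nM to 200000 nM, most likely reported as a limit again.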

Compound 3, half-maximal effective concentration: > 25000 nM
Compound 3: only a limit was reported; the forecaster's own chance of this, stated with the estimate: 75%; the middle value lies beyond the limit too.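

In this assay compound 3 gives > 25000 nM, again a limit of the assay and not a number. Among these compounds, no step among compound 1, compound 2 and compound 3 can be read. The compounds shown leave open whether 1H-pyrazol-3-yl, methyl or piperazin-1-yl on the shared core makes any difference in this assay.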